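The compounds below may be only part of what the source reports. "The series", "measured", "known", "first", "only" and "open" are said of these compounds alone.

Within the data shown here, in a functional assay on SK-OV-3 cells (Homo sapiens) for inhibition, read by CCK-8 assay, with a stated time of 70 h (a higher number here means a weaker inhibitor, a lower number a stronger inhibitor), compound 2 (`c1ccc(COc2ccc(COc3ccc(OCCOCCNC4CCCC4)cc3)cc2)cc1`) gives 10000 nM while compound 1 (`COC(=O)c1ccc(COc2ccc(OCCOCCNC3CCCC3)cc2)cc1`) gives 6990 nM and the two numbers lie within the scatter of each other, so compound 2 stands level with the only other measured compound. Compound 3 (`Cc1ccc(COc2ccc(OCCOCCNC3CCCC3)cc2)cc1`) has methyl in place of benzyloxy on an aromatic carbon, para to a large group (methyl in place of benzyloxy on an aromatic carbon). Among the measured compounds shown here, one measured step bears on this place: the exchange of methoxycarbonyl for benzyloxy came out as a 1.4-fold higher number from compound 1 to compound 2 (0.16 log units; within the scatter) and thus stayed within the scatter. Methyl has not been measured here, so this single step is thin evidence, and no change beyond the scatter is expected in this assay for the new compound. The estimated step is a 1.3-fold lower number from compound 2 to compound 3 (0.10 log units; within the scatter) and it rests on that one comparison. Compound 3 is estimated at 8000 nM with an expected range from 3500 nM to 18000 nM for its measurement.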

Compound 3, half-maximal inhibitory concentration: 17200 nM
Compound 3: the middle estimate sits 2.2-fold (0.33 log units) below what was measured, and the stated range covers the measured number.
By their numbers in this assay, from the lowest: compounds 1, 2 and 3 (each within the scatter of the next, the first and the last beyond it).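

Here this assay puts a 1.7-fold higher number from compound 2 to compound 3 (0.24 log units; within the scatter) and so the loss of the whole benzyloxy group, with its six-membered aromatic ring, leaves methyl on the same aromatic carbon without separating the two compounds. This place does yield a gap beyond the scatter in a 2.5-fold higher number from compound 1 to compound 3 (0.39 log units; beyond the scatter) for methyl in place of methoxycarbonyl, a modest one and the first shown at this place, while compound 2 lies within the scatter of both other compounds. Nothing measured here accounts for this gap.

The three groups shown leave open how a carboxylic acid, an amine or a hydroxyl group on this aromatic carbon would read in this assay and how they would compare with methoxycarbonyl. They also leave open whether any group at this place can give a number far lower than compound 1 shows at 6990 nM in that assay.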